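Swapping the pyridyl for difluorophenyl on a weak pair

The compounds below may be only part of what the source reports. "The series", "measured", "known", "first", "only" and "open" are said of these compounds alone.

Compound 1 `C[C@H](Nc1ncnc2[nH]cnc12)c1nn(-c2ccncc2)c2cc(F)ccc12` gives 21400 nM in a functional assay on Hep 3B2 cells (Homo sapiens) for inhibition, read by sulforhodamine B assay, with a stated time of 72 h (on this read-out lower numbers stand for stronger inhibition and higher numbers for weaker inhibition), the higher of the two numbers measured, while compound 2 `C[C@H](Nc1nc(N)nc(N)c1C#N)c1nn(-c2cccnc2)c2cc(C(F)(F)F)ccc12` gives 9710 nM in this assay, a gap beyond the usual scatter. Compound 3 `C[C@H](Nc1ncnc2[nH]cnc12)c1nn(-c2cc(F)cc(F)c2)c2cc(F)ccc12`, not yet measured, differs from compound 1 by 3,5-difluorophenyl in place of pyridin-4-yl on an aromatic nitrogen. Among the measured compounds shown here, no measured pair shows this change, so the step of a 1.8-fold lower number from compound 1 to compound 3 (0.25 log units; within the scatter) is expected to be small, likely toward a lower number but not certainly beyond the scatter. Compound 3 is estimated at 12000 nM, with a range from 4000 nM to 40000 nM.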

Compound 3, half-maximal inhibitory concentration: > 40000 nM
Compound 3 ended at the assay's limit; the forecaster's own chance of this, stated with the estimate: 10%; middle value at least 3.3-fold (0.52 log units) from the limit.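

At this position, 3,5-difluorophenyl in place of pyridin-4-yl brings no gain on the core of compound 1, giving an at least 1.8-fold higher number from compound 1 to compound 3 (0.27 log units; that floor lies within the scatter) in this assay. Compound 3 stands at a limit of the assay, not at a number: the limit of > 40000 nM in this assay, at which 1 of the 3 values shown sits.

On these data alone, the true size of the step therefore stays unknown, and only its floor can be read. Left open is whether a phenyl ring carrying an amine or a carboxylic acid on this aromatic nitrogen would give a lower number than compound 1, and whether 3,5-difluorophenyl would behave the same way on the core of compound 2.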